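Methyl in Place of Trifluoromethyl: Expected Cytotoxicity

This account rests on a few compounds, and the source may have more. Where it says the series, first, only, none or still open, it means among the compounds named here.

Compound 3 `O=S(=O)(Nc1ccc(-c2nc3ccccc3o2)cc1)c1cccc(C(F)(F)F)c1` is one of three analogues built on a shared core. In an ADME assay on HEK293 cells (Homo sapiens) for cytotoxicity, read by resazurin assay, with a stated time of 48 h (a higher number here means that more compound is tolerated, a lower number that less compound is tolerated), compound 3 gives > 100000 nM, which is a limit of the assay and not a number. Compound 1 `O=S(=O)(Nc1ccc(-c2nc3ccccc3o2)cc1)c1cccc(Cl)c1` gives > 100000 nM in this assay, again a limit. Compound 2 `O=S(=O)(Nc1ccc(-c2nc3ccccc3o2)cc1)c1ccccc1F` gives > 100000 nM in this assay, also a limit. All three therefore sit at the limit of > 100000 nM in this assay, at which 3 of the 3 values shown sit, so compound 3 stands level with its two neighbours and no higher or lower position can be read for it.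

Compound 4 `Cc1cccc(S(=O)(=O)Nc2ccc(-c3nc4ccccc4o3)cc2)c1` differs from compound 3 in one place: methyl in place of trifluoromethyl on an aromatic carbon. The two measured steps, a step that the two limits leave unreadable from compound 1 to compound 2 and a step that the two limits leave unreadable from compound 1 to compound 3, both begin at a limit and end at a limit, so neither gives a readable size, and neither involves a methyl group. The account therefore expects no step beyond the scatter, with a step that the limit leaves unreadable from compound 3 to compound 4 the estimated change. Compound 4 is estimated at 120000 nM, within a range from 50000 nM to 300000 nM, most likely reported again only as a limit.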

Compound 4, half-maximal cytotoxic concentration: > 100000 nM
Compound 4: no number, only a limit; the forecaster's own chance of this, stated with the estimate: 85%; the middle value is on the limit's open side.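

No step can be read from compound 1, compound 2 or compound 3 to compound 4, since all four compounds stand at the same limit: the limit of > 100000 nM in this assay, at which 4 of the 4 values shown sit. The compounds shown leave open how cytotoxicity in this assay differs among them, and at what concentration, if any, each would reach a measurable value.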